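The source may hold more compounds than are shown below. What is called first, only, known or untested is meant among the compounds shown, and "the series" means these compounds.

Of the compounds shown here, three sharing one core have been measured in an ADME assay on HEK-293T cells (Homo sapiens) for cytotoxicity, read by MTT assay, tested at 25 uM; on this read-out lower numbers stand for a stronger effect and higher numbers for a weaker effect at the one concentration tested. Compound 1 `COc1ccc(OC(C)=O)c(C(=O)Nc2ncc([N+](=O)[O-])s2)c1` gives 100%. Compound 2 `O=C(Nc1ncc([N+](=O)[O-])s1)c1ccc([N+](=O)[O-])o1` gives 87.4%. Compound 3 `O=C(Nc1ncc([N+](=O)[O-])s1)c1ccc(-c2ccc(Cl)cc2)o1` gives 75%, the lowest of the three numbers, with compound 2 nearest and compound 1 furthest. Among the compounds with values here, the only step measured between neighbours, a number 12.4 percentage points lower from compound 2 to compound 3 (beyond the scatter), put 4-chlorophenyl in place of nitro on an aromatic carbon.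

Compound 4 `O=C(Nc1ncc([N+](=O)[O-])s1)c1ccc(-c2ccc(Br)cc2)o1` has not yet been measured in this assay. Its difference from compound 3 is bromo in place of chloro on an aromatic carbon, sitting on an aromatic carbon of a six-membered aromatic ring of carbon only. Within the data shown here, no measured step exchanges one halogen for another, so the step from nitro to 4-chlorophenyl does not speak directly to this change; the number of compound 3 itself is the main guide. The expected step is therefore a number 2 percentage points lower from compound 3 to compound 4 (within the scatter), none beyond the scatter. Compound 4 is estimated at 73%, within a range from 60% to 86%.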

Compound 4, a percentage reported as activity, at one concentration (the size of the read-out at that concentration, not a potency): 89.1%
The estimate for compound 4 lay 16.1 percentage points below the measured number; the measured number lies above the stated range.
By their numbers in this assay, from the lowest: compound 3; then compounds 2 and 4 (each within the scatter of the next); then compound 1.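

In this assay, bromo in place of chloro keeps the count at one heavy atom and adds no ring, hydrogen-bond donor, hydrogen-bond acceptor or net charge, yet it gives a number 14.1 percentage points higher from compound 3 to compound 4 (beyond the scatter) and so is not a neutral swap here. Within the data shown here, the read-out at this place, on an aromatic carbon of a six-membered aromatic ring of carbon only and para to a large group, therefore depends on which halogen sits there, something the earlier compounds could not show. Replacing nitro with an aryl group also does not by itself lower the number, since 4-bromophenyl in place of nitro gives a number 1.7 percentage points higher from compound 2 to compound 4 (within the scatter) and only the 4-chlorophenyl step reached beyond the scatter.

Nothing shown here accounts for the gap between the two halogens. On these data alone, whether fluoro, iodo, methyl or an amine at the same place would read like compound 3 or like compound 4 remains open.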